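This account rests on a few compounds, and the source may have more. Where it says the series, first, only, none or still open, it means among the compounds named here.

In a functional assay on T47D cells (Homo sapiens) for cytotoxicity, read by sulforhodamine B assay, with a stated time of 48 h (on this read-out higher numbers stand for weaker inhibition and lower numbers for stronger inhibition), three close relatives of one shared core have been measured. Compound 1 `Cc1cc(NS(=O)(=O)c2ccc(N/C=C\C(=O)c3cc4ccccc4oc3=O)cc2)on1` gives 75600 nM, compound 2 `O=C(/C=C\Nc1ccc(S(=O)(=O)Nc2ccccn2)cc1)c1cc2ccccc2oc1=O` gives 37600 nM, and compound 3 `COc1cnc(NS(=O)(=O)c2ccc(N/C=C\C(=O)c3cc4ccccc4oc3=O)cc2)nc1` gives 8800 nM. The step of a 2.0-fold lower number from compound 1 to compound 2 (0.30 log units; within the scatter) was small, whereas an 8.6-fold lower number from compound 1 to compound 3 (0.93 log units; beyond the scatter) and a 4.3-fold lower number from compound 2 to compound 3 (0.63 log units; beyond the scatter) were both modest but clear, so compound 3 stands as the lowest number of the three, beyond the scatter from each of the others.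

Compound 4 `Nc1ccc(S(=O)(=O)c2ccc(N/C=C\C(=O)c3cc4ccccc4oc3=O)cc2)cc1` differs from compound 3 by 4-aminophenyl in place of (5-methoxypyrimidin-2-yl)amino on a sulfonyl sulfur. For the measured compounds named here, none of the measured steps makes exactly this change: all three vary the group on a sulfonamide nitrogen while keeping that nitrogen, whereas here the (5-methoxypyrimidin-2-yl)amino group is removed altogether and 4-aminophenyl is attached to the sulfonyl sulfur. Those steps do show that this position moves this assay by modest amounts, and that the 5-methoxypyrimidin-2-yl group of compound 3 gave the lowest number. Losing it is therefore expected to raise the number in this assay by a modest step, a 2.8-fold higher number from compound 3 to compound 4 (0.45 log units; beyond the scatter), though with wide uncertainty. Compound 4 is estimated at 25000 nM, within a range of 6000 nM to 100000 nM.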

Compound 4, half-maximal inhibitory concentration: 91900 nM
Compound 4: the middle estimate sits 3.7-fold (0.57 log units) below what was measured; the range from low to high includes it.
By their numbers in this assay, from the lowest: compound 3; then compounds 2, 1 and 4 (each within the scatter of the next, the first and the last beyond it).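

In this assay, removing the sulfonamide nitrogen and placing 4-aminophenyl on the sulfonyl sulfur gives a 10-fold higher number from compound 3 to compound 4 (1.02 log units; beyond the scatter), a large step where the earlier changes at this position were at most modest. The same change is modest when it replaces the (pyridin-2-yl)amino group, at a 2.4-fold higher number from compound 2 to compound 4 (0.39 log units; beyond the scatter), and lies within the scatter when it replaces the (3-methyl-1,2-oxazol-5-yl)amino group, at a 1.2-fold higher number from compound 1 to compound 4 (0.08 log units; within the scatter), so its size depends on the group leaving, and keeping the sulfonamide nitrogen brings a clear gain only with some groups on it. Nothing shown here accounts for these differences.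

Each of these steps changes the nitrogen link and the ring together, so the share of each remains unresolved. From the compounds shown here alone, it also remains open whether a 5-methoxypyrimidin-2-yl ring attached directly to the sulfonyl sulfur would keep the low number, or whether a plain phenyl or 4-hydroxyphenyl group would match 4-aminophenyl.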